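From vinyl to 2-azidoethyl on a shared core

This account rests on a few compounds, and the source may have more. Where it says the series, first, only, none or still open, it means among the compounds named here.

In a functional assay on P388 cells (Mus musculus) for cytotoxicity (on this read-out higher numbers stand for weaker inhibition and lower numbers for stronger inhibition), compound 3 `C=CC[C@@H]1NC(=O)[C@@H](C)NC(=O)[C@@H]2Cc3ccc(OC)c(c3)Oc3ccc(cc3)C[C@@H](C(=O)N2C)N(C)C(=O)[C@H](C)NC(=O)[C@H](Cc2ccc(OC)cc2)N(C)C1=O` gives 38.9 nM. Compound 1 `COC(=O)CC[C@@H]1NC(=O)[C@@H](C)NC(=O)[C@@H]2Cc3ccc(OC)c(c3)Oc3ccc(cc3)C[C@@H](C(=O)N2C)N(C)C(=O)[C@H](C)NC(=O)[C@H](Cc2ccc(OC)cc2)N(C)C1=O` gives 58.9 nM, which lies within the usual scatter of the value for compound 3, so the two cannot be ranked. Compound 2 `COc1ccc(C[C@H]2C(=O)N[C@@H](C)C(=O)N(C)[C@H]3Cc4ccc(cc4)Oc4cc(ccc4OC)C[C@@H](C(=O)N[C@H](C)C(=O)NC4(SCCS4)C(=O)N2C)N(C)C3=O)cc1` gives 631 nM, a clearly higher number and so weaker inhibition, but it is not linked to either of the others by a change in one place.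

Compound 4 `COc1ccc(C[C@H]2C(=O)N[C@@H](C)C(=O)N(C)[C@H]3Cc4ccc(cc4)Oc4cc(ccc4OC)C[C@@H](C(=O)N[C@H](C)C(=O)N[C@@H](CCCN=[N+]=[N-])C(=O)N2C)N(C)C3=O)cc1` has not yet been measured. It carries 2-azidoethyl in place of vinyl on a saturated chain carbon bound to a saturated ring carbon. Going by the values given here, one measured step bears on this place: a 1.5-fold lower number from compound 1 to compound 3 (0.18 log units; within the scatter), where vinyl replaced (methoxycarbonyl)methyl, and it stayed within the scatter. Among the compounds with values here, a single step is thin evidence, and no compound with an azide has a measured value. Even so, nothing measured points to a large shift in either direction. The step expected in this assay is a 1.3-fold higher number from compound 3 to compound 4 (0.11 log units; within the scatter), which stays within the scatter. Compound 4 is estimated at 50 nM, with an expected range from 20 nM to 130 nM.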

Compound 4, half-maximal inhibitory concentration: 35.5 nM
The estimate for compound 4 lay 1.4-fold (0.15 log units) above the measured number; the measured number falls inside the stated range.
By their numbers in this assay, from the lowest: compounds 4, 3 and 1 (each within the scatter of the next); then compound 2.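

In this assay the step of a 1.1-fold lower number from compound 3 to compound 4 (0.04 log units; within the scatter) and the step of a 1.7-fold lower number from compound 1 to compound 4 (0.22 log units; within the scatter) both stay within the scatter, so compounds 1, 3 and 4 cannot be ranked. This adds something new: the place on a saturated chain carbon bound to a saturated ring carbon now accepts 2-azidoethyl, with 5 heavy atoms including 3 nitrogens, in place of vinyl, with 2 heavy atoms, and the number shows no measurable shift. Nothing measured here explains why the numbers stay so close.

From the compounds shown here alone, whether an amine or a carboxylic acid in place of the 2-azidoethyl would stay in the same range remains open. So does the effect of a longer chain carrying the azide, since the three compounds compared cover only a narrow set of groups at this place.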